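Sulfanyl to carboxy on the diketopiperazine side chain

This account rests on a few compounds, and the source may have more. Where it says the series, first, only, none or still open, it means among the compounds named here.

Compound 1 `CC(C)C[C@@H]1NC(=O)[C@H](CS)NC1=O` stands highest of the two numbers measured in a functional assay, tested at 2.5 mM (on this read-out lower numbers stand for less inhibition and higher numbers for more inhibition at the one concentration tested (going by the name of the read-out)), where compound 1 gives 83.3%; in this assay compound 2 `CC(C)C[C@@H]1NC(=O)[C@H](C)NC1=O` gives 0%. Within the data shown here, the only step that bears on the change in hand is a number 83.3 percentage points lower from compound 1 to compound 2 (beyond the scatter), so removing the sulfanyl left no inhibition. Compound 3 `CC(C)C[C@@H]1NC(=O)[C@H](CC(=O)O)NC1=O` differs from compound 1 by carboxy in place of sulfanyl on a saturated chain carbon bound to a saturated ring carbon. Because a number 83.3 percentage points lower from compound 1 to compound 2 (beyond the scatter) was this large, a step down is expected here too, although carboxy does not vanish as hydrogen did, so the size is uncertain; the expected step is a number 58.3 percentage points lower from compound 1 to compound 3 (beyond the scatter). For compound 3 the estimate is 25%, with a range from 0% to 70%.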

Compound 3, a percentage reported as inhibition, at one concentration (the size of the read-out at that concentration, not a potency): 0%
Compound 3: the middle estimate sits 25 percentage points above what was measured; low and high end bracket the measured number.
By their numbers in this assay, from the lowest: compounds 2 and 3 (each within the scatter of the next); then compound 1.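

In this assay, replacing sulfanyl with carboxy on a saturated chain carbon bound to a saturated ring carbon gives a number 83.3 percentage points lower from compound 1 to compound 3 (beyond the scatter) in this series. Against hydrogen at the same place, carboxy gives no change at the digits printed from compound 2 to compound 3 (within the scatter), so of the three groups compared, only sulfanyl goes with inhibition at the one concentration tested. Nothing available explains this difference between sulfanyl and carboxy.

Still open, as far as these compounds go, is whether a hydroxy group or an amine at this place would give any inhibition. Also open, from the compounds shown here alone, is how sulfanyl would behave on a longer chain.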